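Fluoro on the phenyl ring of compound 1

The source may hold more compounds than are shown below. What is called first, only, known or untested is meant among the compounds shown, and "the series" means these compounds.

In a functional assay on the whole organism (strain CD1) with Mus musculus as the target, in the maximal electroshock model, with a stated time of 4 h (a lower number here means that less compound is needed, a higher number that more compound is needed for the effect), compound 1 `CC(C)C1(C(C)C)NC(=O)N(CN2CCN(c3ccccc3)CC2)C1=O` gives 300 mg/kg, the highest of the three numbers at hand. Compound 2 `O=C1NC(c2ccccc2)(c2ccccc2)C(=O)N1CN1CCN(c2cccc(C(F)(F)F)c2)CC1` gives 100 mg/kg in this assay, and compound 3 `CN1CCN(CN2C(=O)NC(c3ccccc3)(c3ccccc3)C2=O)CC1` gives 10 mg/kg. Among the compounds with values here, the one step that can be followed in one place runs a 10-fold lower number from compound 2 to compound 3 (1.00 log units; beyond the scatter), a change of a methyl in place of a 3-(trifluoromethyl)phenyl on an amine nitrogen in a ring.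

Compound 4 `CC(C)C1(C(C)C)NC(=O)N(CN2CCN(c3ccccc3F)CC2)C1=O` differs from compound 1 as follows: fluoro in place of hydrogen on an aromatic carbon. Cut one bond further out, the change reads phenyl to 2-fluorophenyl. Within the data shown here, none of the measured steps bears on this change; the only step measured concerns a different place in the shared core, and the two compounds that share the diisopropyl-bearing core, compound 1 and compound 4, offer no earlier comparison of this kind. The expectation is therefore a step of no change at the digits printed from compound 1 to compound 4 (within the scatter), not beyond the scatter. Compound 4 is estimated in this assay at 300 mg/kg, with a range from 100 mg/kg to 600 mg/kg.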

Compound 4, minimum effective dose: 100 mg/kg
For compound 4 the middle estimate is 3.0-fold (0.48 log units) above the measured one; the range from low to high includes it.
By their numbers in this assay, from the lowest: compound 3; then compounds 2 and 4 (each within the scatter of the next); then compound 1.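

In this assay, the step of a 3.0-fold lower number from compound 1 to compound 4 (0.48 log units; beyond the scatter) shows that a single fluoro in place of hydrogen, on an aromatic carbon ortho to a large group, is enough to shift the dose beyond the scatter. The earlier step, a 10-fold lower number from compound 2 to compound 3 (1.00 log units; beyond the scatter), exchanged the entire aromatic group for a methyl, so it could not show how a small change on the phenyl ring itself reads in this assay. Nothing at hand gives a reason for the step.

As far as these compounds go, it remains open whether a chloro, a methoxy or a methyl at this same place would move the dose as fluoro does, or whether fluoro at another carbon of the ring would. From the compounds shown here alone, the same fluoro on a phenyl ring attached to the core of compound 2 also remains open.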